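The source may hold more compounds than are shown below. What is called first, only, known or untested is meant among the compounds shown, and "the series" means these compounds.

Compound 2 `Cc1ccc(S(=O)(=O)c2cnc3ccc(C)cc3c2N2CCC(C)CC2)cc1` stands lowest of the two measured numbers: in an assay on isolated protein for displacement of a labelled ligand from metabotropic glutamate receptor 5 (Homo sapiens), with a stated time of 60 min, tested at 1 uM (on this read-out lower numbers stand for less inhibition and higher numbers for more inhibition at the one concentration tested (going by the name of the read-out)), compound 2 gives 82%. Its nearest neighbour is compound 1 `Cc1ccc2ncc(S(=O)(=O)c3ccc(F)c(Cl)c3)c(N3CCC(C)CC3)c2c1`, which in this assay gives 93%. Among the measured compounds shown here, the one measured step, a number 11 percentage points lower from compound 1 to compound 2 (beyond the scatter), bears directly on the next change, as it ran over the same sulfonyl position in the reverse sense. Compound 3 `Cc1ccc2ncc(S(=O)(=O)c3cccc(Cl)c3)c(N3CCC(C)CC3)c2c1` differs from compound 2 as follows: 3-chlorophenyl in place of 4-methylphenyl on a sulfonyl sulfur. The entering 3-chlorophenyl shares its chlorine with the 3-chloro-4-fluorophenyl of compound 1. A modest rise is therefore expected, estimated as a number 8 percentage points higher from compound 2 to compound 3 (within the scatter). Compound 3 is expected to give about 90% in this assay, with a range from 80% to 97%.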

Compound 3, a percentage reported as inhibition, at one concentration (the size of the read-out at that concentration, not a potency): 91%
Estimate against measurement, compound 3: 1 percentage points below; the range from low to high includes it.
By their numbers in this assay, from the lowest: compounds 2, 3 and 1 (each within the scatter of the next, the first and the last beyond it).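

In this assay, the step of a number 2 percentage points lower from compound 1 to compound 3 (within the scatter) shows that hydrogen in place of fluoro on an aromatic carbon does not move the reading outside the scatter. The step of a number 9 percentage points higher from compound 2 to compound 3 (within the scatter) also stays within the scatter, so 3-chlorophenyl and 4-methylphenyl on the sulfonyl sulfur cannot be told apart here, even though compound 1 and compound 2 differ beyond it. Nothing available explains these readings. Still open, from the compounds shown here alone, is how the reading would respond to an amine or a carboxylic acid on this phenyl, and a single-concentration read-out gives no potency.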